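The compounds below may be only part of what the source reports. "The series", "measured", "known", "first", "only" and "open" are said of these compounds alone.

Three compounds share one core and differ in the group on the outer aromatic ring and in the small substituent on the central ring. In a functional assay on A549 cells (Homo sapiens) for antiproliferative activity, read by MTT assay, with a stated time of 48 h (on this read-out lower numbers stand for stronger inhibition and higher numbers for weaker inhibition), compound 1 `C=CC(=O)Nc1cccc(Nc2nc(Nc3ccc(OCCn4ccnc4)cc3)ncc2F)c1` gives 8370 nM, and compound 2 `C=CC(=O)Nc1cccc(Nc2nc(Nc3ccc(Cn4ccnc4)cc3OC)ncc2Cl)c1` gives 14300 nM. Compound 3 `C=CC(=O)Nc1cccc(Nc2nc(Nc3ccc(-n4ccnc4)cc3)ncc2[N+](=O)[O-])c1` reaches only the limit of this assay, > 40000 nM, which is a limit rather than a number (the limit of > 40000 nM in this assay, at which 1 of the 3 values shown sits). Compound 4 `C=CC(=O)Nc1cccc(Nc2nc(Nc3ccc(OCCCn4ccnc4)cc3)ncc2[N+](=O)[O-])c1` differs from compound 3 by 3-(1H-imidazol-1-yl)propoxy in place of 1H-imidazol-1-yl on an aromatic carbon. Compound 1 and compound 2 both carry a linker between the outer ring and the imidazole and both give measured numbers, while compound 3 does not. On that basis the step of an at least 1.6-fold lower number from compound 3 to compound 4 (0.20 log units; that floor lies within the scatter) is expected to be modest and toward stronger inhibition. Compound 4 is estimated at 25000 nM, between 7000 nM and 90000 nM.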

Compound 4, half-maximal inhibitory concentration: 27400 nM
Compound 4: middle estimate off by 1.1-fold (0.04 log units), on the low side, within the range that was stated.
By their numbers in this assay, from the lowest: compounds 1, 2 and 4 (each within the scatter of the next, the first and the last beyond it). At a limit, above all of these: compound 3.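

In this assay, going by these compounds alone, putting 3-(1H-imidazol-1-yl)propoxy on this aromatic carbon gives the first step at this position that can be read, an at least 1.4-fold lower number from compound 3 to compound 4 (0.16 log units; that floor lies within the scatter). Compound 4 has a measured number, but this floor does not show that the longer group strengthens inhibition. The true size of the step stays unknown because compound 3 sits at a limit: the limit of > 40000 nM in this assay, at which 1 of the 4 values shown sits.

The compounds shown leave open whether a longer chain before the imidazole, or an amine in its place, would change the number with the rest of compound 4 kept the same.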